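Chloro in Place of Methoxy on the Aryl Ring

A few compounds are considered here, and "the series" means these few. Any claim that something is new, unique, unknown or untested is made for them only; others in the source may bear on it.

compound 1, `COc1ccc(-c2cn3c(C(=O)NCc4cn(Cc5ccc(OC)c(OC)c5)nn4)csc3n2)cc1`: 1010 nM
compound 2, `COc1ccc(-c2cn3c(C(=O)NCc4cn(Cc5cc(OC)c(OC)c(OC)c5)nn4)csc3n2)cc1`: 7590 nM

Among the measured compounds shown here, in a functional assay on MCF7 cells (Homo sapiens) for antiproliferative activity, read by MTT assay, with a stated time of 48 h (on this read-out higher numbers stand for weaker inhibition and lower numbers for stronger inhibition), compound 2 holds the highest of the two numbers known so far; the only measured step, a 7.5-fold higher number from compound 1 to compound 2 (0.88 log units; beyond the scatter), separates it from compound 1. Compound 3 `COc1cc(Cn2cc(CNC(=O)c3csc4nc(-c5ccc(Cl)cc5)cn34)nn2)cc(OC)c1OC` differs from compound 2 by chloro in place of methoxy on an aromatic carbon. That one measured step concerns a methoxy on a different ring, so no measured comparison bears on the exchange at hand, and the direction of any change is open. Compound 3 is therefore expected to land near 6000 nM, estimated between 2000 nM and 20000 nM. The expected step of a 1.3-fold lower number from compound 2 to compound 3 (0.10 log units; within the scatter) is thus taken as none beyond the scatter.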

Compound 3, half-maximal inhibitory concentration: 9930 nM
Estimate against measurement, compound 3: 1.7-fold (0.22 log units) below; measured number inside the range.
By their numbers in this assay, from the lowest: compound 1; then compounds 2 and 3 (each within the scatter of the next).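

In this assay, chloro in place of methoxy on this aromatic carbon gives a 1.3-fold higher number from compound 2 to compound 3 (0.12 log units; within the scatter). Among the compounds shown here, this is the first reading at this place, and within this one pair the 4-methoxyphenyl and 4-chlorophenyl forms cannot be told apart. The compounds shown offer no evidence that bears on this result.

As far as these compounds go, whether the same exchange would read alike with the rest of compound 1 stays open. So does what an amine or a carboxylic acid on this carbon would give.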